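A Methoxy Group Added to a Compound Without Measured Activity

The source may report more compounds than this note shows. Statements on the series, on what has been measured and on what is new or still open speak of the compounds shown alone.

Measured so far:
Compound 1, `Cc1nc(SCC(=O)Nc2nc(-c3ccc(Cl)cc3)cs2)n(Nc2ccccc2)c1C`: > 100000 nM
Compound 2, `Cc1ccc(Nn2c(SCC(=O)Nc3nc(-c4ccccc4)cs3)nc(C)c2C)cc1`: > 100000 nM

In a functional assay on NCI-H322M cells (Homo sapiens) for antiproliferative activity, read by sulforhodamine B assay, with a stated time of 48 h (a higher number here means that more compound is tolerated, a lower number that less compound is tolerated), compound 1 reaches only a limit of the assay, not a number: it stands at the limit of > 100000 nM in this assay, at which 2 of the 2 values shown sit. The value for compound 2 in this assay is likewise a limit. Compound 3, `COc1ccc(Nn2c(SCC(=O)Nc3nc(-c4ccc(Cl)cc4)cs3)nc(C)c2C)cc1`, differs from compound 1 by methoxy in place of hydrogen on an aromatic carbon. Among the measured compounds shown here, no step between measured compounds is available, so nothing here shows how such a change shifts this assay; with compound 1 at a limit, the expected step from compound 1 to compound 3 is a number no higher from compound 1 to compound 3 (the limit leaves the size open), nothing beyond the scatter. Compound 3 is therefore expected at 100000 nM, in the range 30000 nM to 300000 nM, most likely again only as a limit.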

Compound 3, concentration lethal to 50% of the cells: > 100000 nM
Compound 3: no number, only a limit (the forecaster's own chance of this, stated with the estimate: 85%); the middle value sits exactly at the limit.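

The step from compound 1 to compound 3 cannot be read, because both compounds give only a limit and no number: the limit of > 100000 nM in this assay, at which 3 of the 3 values shown sit. Going by these compounds, whether methoxy in place of hydrogen on an aromatic carbon changes the activity at all stays open.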